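Methoxy removal on the aryl of compound 1

A few compounds are considered here, and "the series" means these few. Any claim that something is new, unique, unknown or untested is made for them only; others in the source may bear on it.

Among the compounds with values here, compound 1 `COc1ccc(-c2nn3cc(-c4cccc(N)c4)nc3s2)cc1OC` is the only member of this set with a numerical result: in a functional assay on L1210 cells (Mus musculus) for inhibition, read by cell counting, with a stated time of 2 days (on this read-out higher numbers stand for weaker inhibition and lower numbers for stronger inhibition), compound 1 gives 16000 nM. Compound 2 `COc1ccc(-c2nn3cc(-c4cccc(N)c4)nc3s2)cc1` differs from it by hydrogen in place of methoxy on an aromatic carbon. In this assay compound 2 reaches only a limit of the assay, >= 250000 nM, not a number. The step of an at least 15-fold higher number from compound 1 to compound 2 (1.19 log units; beyond the scatter) shows that dropping a methoxy from compound 1 costs a great deal of inhibition, with the end point sitting at the limit of >= 250000 nM in this assay, at which 1 of the 2 values shown sits.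

Compound 3 `COc1cccc(-c2nn3cc(-c4cccc(N)c4)nc3s2)c1` is still to be measured in this assay. Its change from compound 1 is hydrogen in place of methoxy on an aromatic carbon. Within the data shown here, the one measured step that bears on this is an at least 15-fold higher number from compound 1 to compound 2 (1.19 log units; beyond the scatter), a large loss. A comparable loss is expected here, so the number should rise well beyond the scatter and may again end at the limit of the assay.

Compound 3 is therefore estimated at 120000 nM in this assay, with a range of 30000 nM to 300000 nM, which means an expected step of a 7.5-fold higher number from compound 1 to compound 3 (0.88 log units; beyond the scatter).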

Compound 3, half-maximal inhibitory concentration: > 250000 nM
Compound 3: only a limit was reported (the forecaster's own chance of this, stated with the estimate: 45%); middle value at least 2.0-fold (0.31 log units) away from the limit.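

Replacing the methoxy that sits para to a large group with hydrogen, while the other methoxy stays, gives an at least 15-fold higher number from compound 1 to compound 3 (1.19 log units; beyond the scatter) in this assay, so this position does not tolerate plain hydrogen either. Compound 3 stands at > 250000 nM, which is a limit of the assay and not a number. Compound 2 and compound 3 each keep one methoxy and neither gives a number, so among these three compounds a numerical result in this assay appears only with both methoxy groups present, and one methoxy alone does not give it.

The true size of each loss stays unread, and no order between compound 2 and compound 3 can be given, since each of them is known only as a limit. Also open, on these data alone, is whether the position para to a large group needs a methoxy as such, or whether an ethoxy, a hydroxyl or a fluorine there, with the other methoxy kept, would hold the result of compound 1 at 16000 nM.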